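The source may report more compounds than this note shows. Statements on the series, on what has been measured and on what is new or still open speak of the compounds shown alone.

In a functional assay on BT-474 cells (Homo sapiens) for antiproliferative activity, read by MTT assay, with a stated time of 72 h (a lower number here means a stronger inhibitor, a higher number a weaker inhibitor), compound 1 `CC(Oc1ncnc2ccc(-c3cnn(C4CCNCC4)c3)cc12)c1c(Cl)ccc(F)c1Cl` gives 4140 nM and compound 2 `CC(Nc1ncnc2ncc(-c3cnn(C4CCNCC4)c3)cc12)c1c(Cl)ccc(F)c1Cl` gives 13500 nM. Compound 2 therefore has the higher of the two numbers, which makes it the weaker inhibitor, and the gap between them lies beyond the usual scatter. The next compound to test is compound 3 `CC(Nc1ncnc2ncc(-c3cnn(C)c3)cc12)c1c(Cl)ccc(F)c1Cl`, which keeps the core of compound 2 but has methyl in place of piperidin-4-yl on an aromatic nitrogen. Compound 1 and compound 2 both carry the piperidin-4-yl group, so neither shows what this swap does. With no measured guide, no shift beyond the scatter is expected in this assay, in either direction. The expected change, a 1.1-fold higher number from compound 2 to compound 3 (0.05 log units; within the scatter), is accordingly small. The estimated value for compound 3 is 15000 nM, with a range from 4500 nM to 50000 nM.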

Compound 3, half-maximal inhibitory concentration: > 100000 nM
Compound 3 was reported as a limit (the forecaster's own chance of this, stated with the estimate: 20%); middle value at least 6.6-fold (0.82 log units) away from the limit.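

In this assay, the group on this aromatic nitrogen turns out to matter: methyl in place of piperidin-4-yl gives an at least 7.4-fold higher number from compound 2 to compound 3 (0.86 log units; beyond the scatter), something compound 1 and compound 2 could not show, as both carry piperidin-4-yl. Compound 3 is reported only as a limit, not as a number: the limit of > 100000 nM in this assay, at which 1 of the 3 values shown sits. Within this one pair, the larger piperidin-4-yl, with its ring, hydrogen-bond donor and hydrogen-bond acceptor, goes with the stronger inhibition, and the small methyl does not keep that activity.

Which feature of piperidin-4-yl counts stays open, since this single step changes size, ring and hydrogen-bonding groups together. A cyclohexyl group, which keeps a ring without the nitrogen, or a short chain ending in an amine, which keeps a nitrogen without the ring, would separate these features.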